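Trifluoromethyl for methoxy in a series at the limit

The source may report more compounds than this note shows. Statements on the series, on what has been measured and on what is new or still open speak of the compounds shown alone.

In a functional assay on PC-3 cells (Homo sapiens) for antiproliferative activity, with a stated time of 48 h (on this read-out lower numbers stand for stronger inhibition and higher numbers for weaker inhibition), compound 1 (`CCN(CC)c1ccc(-c2cccc(OC)c2)nn1`) gives > 25000 nM as a limit of the assay and not a number. Compound 2 (`CC(=O)c1ccc(-c2ccc(N3CCCC3)nn2)cc1`) gives > 25000 nM on the same read-out, again a limit. Compound 3 (`COC(=O)c1cccc(-c2ccc(-n3cccc3)nn2)c1`) gives > 25000 nM on the same read-out, also a limit. Compound 1 thus stands at the limit of > 25000 nM in this assay, at which 3 of the 3 values shown sit, and has no number of its own. Among the compounds with values here, no order among the three can be told, and no step between measured compounds is available to scale from.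

Compound 4 (`CCN(CC)c1ccc(-c2cccc(C(F)(F)F)c2)nn1`) keeps the core of compound 1 and carries trifluoromethyl in place of methoxy on an aromatic carbon, meta to a large group (trifluoromethyl in place of methoxy on an aromatic carbon). The only anchor for the next reading is compound 1 with its limit of > 25000 nM and nothing firmer. In this assay no change beyond the scatter is expected, and another reading at the limit is the likeliest outcome. The expected size of the change is a step that the limit leaves unreadable from compound 1 to compound 4 in this estimate. For compound 4 the estimated value is 30000 nM with an expected range of 12000 nM to 60000 nM on the same read-out.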

Compound 4, half-maximal inhibitory concentration: > 25000 nM
Compound 4: only a limit was reported (the forecaster's own chance of this, stated with the estimate: 80%); the middle value does not contradict the limit.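

Compound 1 and compound 4 are both reported only as limits in this assay, so no step between them can be read: the limit of > 25000 nM in this assay, at which 4 of the 4 values shown sit.

The compounds shown leave open how trifluoromethyl and methoxy compare on the shared core, and whether any of these compounds would give a number rather than a limit in this assay.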